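A Cyclobutyl Group at the Double-Bonded Chain Carbon

The source may report more compounds than this note shows. Statements on the series, on what has been measured and on what is new or still open speak of the compounds shown alone.

Compound 1, `CCC/C(=C(/c1ccc(/C=C/C(=O)O)cc1)c1ccc2[nH]ncc2c1)c1ccccc1`, gives 11 nM in a functional assay on MCF7 cells (Homo sapiens) for cytotoxicity, read by CellTiter-Glo, with a stated time of 5 days; a lower number here means a stronger inhibitor, a higher number a weaker inhibitor.
Compound 2, `O=C(O)/C=C/c1ccc(/C(=C(/CCO)c2ccccc2)c2ccc3[nH]ncc3c2)cc1`, reaches only a limit of this assay, > 1000 nM.
Compound 3, `O=C(O)/C=C/c1ccc(/C(=C(\c2ccccc2)C(F)F)c2ccc3[nH]ncc3c2)cc1`, gives 14 nM in this assay.

Of the two compounds with a number, compound 3 has the larger one, yet a 1.3-fold higher number from compound 1 to compound 3 (0.10 log units; within the scatter) falls within the scatter, so compound 1 and compound 3 cannot be told apart. Compound 2 stands apart: an at least 71-fold lower number from compound 2 to compound 3 (1.85 log units; beyond the scatter). Within that pair the only difference is the hydroxy group, which is also what sets compound 2 apart from compound 1 in an at least 90-fold higher number from compound 1 to compound 2 (1.95 log units; beyond the scatter). The new compound 4, `O=C(O)/C=C/c1ccc(/C(=C(\c2ccccc2)C2CCC2)c2ccc3[nH]ncc3c2)cc1`, changes compound 3 as follows: cyclobutyl in place of difluoromethyl on a double-bonded chain carbon bound to an aromatic carbon and a double-bonded chain carbon. The entering group, like the propyl of compound 1 and the difluoromethyl of compound 3, carries no hydrogen-bond donor or acceptor, so the step that bears on it is the small one, a 1.3-fold higher number from compound 1 to compound 3 (0.10 log units; within the scatter), not the large loss seen with compound 2. The expected step is therefore a 1.1-fold higher number from compound 3 to compound 4 (0.03 log units; within the scatter), none beyond the scatter. Compound 4 is thus estimated at 15 nM, with a range from 6 nM to 45 nM.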

Compound 4, half-maximal inhibitory concentration: 1.4 nM
Compound 4: the middle estimate sits 11-fold (1.03 log units) above what was measured, outside the stated range (below it).
By their numbers in this assay, from the lowest: compound 4; then compounds 1 and 3 (each within the scatter of the next). At a limit, above all of these: compound 2.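

In this assay, propyl and difluoromethyl could not be told apart at this double-bonded chain carbon, but cyclobutyl separates from both: a 10-fold lower number from compound 3 to compound 4 (1.00 log units; beyond the scatter) and a 7.9-fold lower number from compound 1 to compound 4 (0.90 log units; beyond the scatter). Having no hydrogen-bond donor or acceptor in the entering group is therefore not enough to predict the number here, since compounds 1, 3 and 4 all share that feature and compound 4 still stands apart. The range at this place also widens to an at least 710-fold lower number from compound 2 to compound 4 (2.85 log units; beyond the scatter), though that step is only a bound, since the value of compound 2 is a limit and not a number: the limit of > 1000 nM in this assay, at which 1 of the 4 values shown sits.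

The compounds shown cannot say whether the ring of cyclobutyl or simply the size of the group accounts for the lower number. From the compounds shown here alone, how a cyclopropyl or cyclopentyl ring, or an amine on the ring, would behave at this carbon remains open.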